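The compounds below may be only part of what the source reports. "The series", "measured", "known", "first", "only" and "open" are said of these compounds alone.

Measured in a functional assay on HCT-116 cells (Homo sapiens) for inhibition, read by MTT assay, with a stated time of 48 h; on this read-out higher numbers stand for weaker inhibition and lower numbers for stronger inhibition:
- compound 1 `COc1ccc(-n2c(SCc3ccc(F)cc3)nnc2-c2cc(OC)c(OC)c(OC)c2)cc1`: 38700 nM
- compound 2 `COc1ccc(C(=O)CSc2nnc(-c3cc(OC)c(OC)c(OC)c3)n2-c2ccc(OC)cc2)cc1`: > 60000 nM (a limit)

Compound 2 gives only a limit and no number: it stands at the limit of > 60000 nM in this assay, at which 1 of the 2 values shown sits.

Compound 3 `COc1ccc(-n2c(SCC(=O)c3ccc(F)cc3)nnc2-c2cc(OC)c(OC)c(OC)c2)cc1` follows from compound 2 by one change, fluoro in place of methoxy on an aromatic carbon, para to a large group.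

For the measured compounds named here, only one measured step bears on this, an at least 1.5-fold higher number from compound 1 to compound 2 (0.19 log units; that floor lies within the scatter). It alters the same side chain but does not isolate this swap, and its size is known only as a floor. Compound 1, which also carries a 4-fluorophenyl, gives 38700 nM. A modest shift towards lower numbers in this assay is therefore expected, though perhaps none beyond the scatter, and another limit reading would not surprise.

The expected step is an at least 1.4-fold lower number from compound 2 to compound 3 (0.15 log units; that floor lies within the scatter). For compound 3 the estimate is 42000 nM, with an expected range from 15000 nM to 100000 nM.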

Compound 3, half-maximal inhibitory concentration: > 60000 nM
Compound 3: only a limit was reported (the forecaster's own chance of this, stated with the estimate: 40%); middle value at least 1.4-fold (0.15 log units) from the limit.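

In this assay compound 3 gives > 60000 nM, which is a limit and not a number, so fluoro in place of methoxy on this aromatic carbon, para to a large group, does not bring a measurable value. For the compounds shown here, the step between compound 2 and compound 3 cannot be read, and the two compounds stay together at the limit: the limit of > 60000 nM in this assay, at which 2 of the 3 values shown sit. Compound 1 and compound 3 both carry the 4-fluorophenyl, so this pair isolates the carbonyl for the first time, and (4-fluorophenyl)carbonyl in place of 4-fluorophenyl gives an at least 1.5-fold higher number from compound 1 to compound 3 (0.19 log units; that floor lies within the scatter).

On these data alone, whether compound 2 and compound 3 differ at all beyond the limit stays open. So does whether an amine or a hydroxy group on this aromatic carbon would give a readable value with the carbonyl in place.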